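The source may report more compounds than this note shows. Statements on the series, on what has been measured and on what is new or still open speak of the compounds shown alone.

Within the data shown here, in a functional assay on MCF7 cells (Homo sapiens) for antiproliferative activity, read by MTT assay, with a stated time of 72 h (a higher number here means a weaker inhibitor, a lower number a stronger inhibitor), compound 1 `CCOC(=O)c1oc2ccc(NS(=O)(=O)c3cccc(Cl)c3)cc2c1C` gives 83900 nM, the higher of the two numbers measured so far. Compound 2 `CCOC(=O)c1oc2ccc(NS(=O)(=O)c3ccc(C(F)(F)F)cc3)cc2c1C` gives 48700 nM in this assay, and the two values lie within the usual scatter of each other. Compound 3 `CCOC(=O)c1oc2ccc(NS(=O)(=O)c3ccccc3[N+](=O)[O-])cc2c1C` has not been measured; it differs from compound 1 by 2-nitrophenyl in place of 3-chlorophenyl on a sulfonyl sulfur. Among the measured compounds shown here, no measured pair shows a change of this kind, so the step from compound 1 to compound 3 is expected to stay within the scatter, with no clear direction: a 1.2-fold lower number from compound 1 to compound 3 (0.08 log units; within the scatter). Compound 3 is therefore estimated at 70000 nM, within a range from 30000 nM to 160000 nM.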

Compound 3, half-maximal inhibitory concentration: 157000 nM
Beside the measured number, compound 3's estimate is 2.2-fold (0.35 log units) below it; low and high end bracket the measured number.
By their numbers in this assay, from the lowest: compounds 2, 1 and 3 (each within the scatter of the next, the first and the last beyond it).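

Placing 2-nitrophenyl in place of 3-chlorophenyl on a sulfonyl sulfur gives a 1.9-fold higher number from compound 1 to compound 3 (0.27 log units; within the scatter) in this assay. Among these compounds, this position therefore accepts a group with more heavy atoms and two hydrogen-bond acceptors without a change beyond the scatter, though this is only one pair of compounds. Nothing available explains this result. As far as these compounds go, whether a phenyl ring carrying an amine or a carboxylic acid would shift the number beyond the scatter remains open. So does the outcome of replacing the ring with a simple alkyl chain.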